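Nitro for Ethoxy in a Spiro Series: Expected Activity

A few compounds are considered here, and "the series" means these few. Any claim that something is new, unique, unknown or untested is made for them only; others in the source may bear on it.

Compound 3 `CCOc1ccc(-n2nncc2CN2C(=O)C3(C(C#N)=C(N)Oc4c(N)cc5nc6ccccc6nc5c43)c3ccccc32)cc1` is one of three measured members of a shared core. In a functional assay on A549 cells (Homo sapiens) for antiproliferative activity, read by MTT assay, with a stated time of 48 h (a lower number here means a stronger inhibitor, a higher number a weaker inhibitor), compound 3 reports only a limit, > 50000 nM. Compound 1 `COc1ccc(-n2nncc2CN2C(=O)C3(C(C#N)=C(N)Oc4c(N)cc5nc6ccccc6nc5c43)c3ccccc32)cc1` likewise reports only a limit, > 50000 nM, in this assay. Compound 2 `COc1ccccc1-n1nncc1CN1C(=O)C2(C(C#N)=C(N)Oc3c(N)cc4nc5ccccc5nc4c32)c2ccccc21` gives 37500 nM in this assay. The steps of an at least 1.3-fold lower number from compound 1 to compound 2 (0.12 log units; that floor lies within the scatter) and an at least 1.3-fold higher number from compound 2 to compound 3 (0.12 log units; that floor lies within the scatter) have floors that stay within the scatter, and the step that the two limits leave unreadable from compound 1 to compound 3 cannot be read at all, as the limit of > 50000 nM in this assay, at which 2 of the 3 values shown sit, shows. Compound 4 `N#CC1=C(N)Oc2c(N)cc3nc4ccccc4nc3c2C12C(=O)N(Cc1cnnn1-c1ccc([N+](=O)[O-])cc1)c1ccccc12` differs from compound 3 by nitro in place of ethoxy on an aromatic carbon. Going by the values given here, none of the measured steps touches an exchange of ethoxy for nitro, so the expectation rests on compound 3 standing at its limit > 50000 nM. Compound 4 is expected to give about 45000 nM in this assay, most probably again only a limit, within a range from 15000 nM to 150000 nM. The step of an at least 1.1-fold lower number from compound 3 to compound 4 (0.04 log units; that floor lies within the scatter) is thus estimated to remain within the scatter, with no direction claimed.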

Compound 4, half-maximal inhibitory concentration: > 50000 nM
Compound 4 was reported as a limit; the forecaster's own chance of this, stated with the estimate: 65%; middle value at least 1.1-fold (0.04 log units) away from the limit.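

In this assay compound 4 reports only a limit, > 50000 nM, so nitro on this aromatic carbon, para to a large group, gives no readable number, just as methoxy and ethoxy did not. Compared with the one member of the series that has a number, the result is an at least 1.3-fold higher number from compound 2 to compound 4 (0.12 log units; that floor lies within the scatter). The steps that join compound 4 to compound 1 and to compound 3 cannot be read, because both ends of each are limits: the limit of > 50000 nM in this assay, at which 3 of the 4 values shown sit.

The compounds shown leave open whether any other group at this place, such as an amine, a carboxylic acid or a longer chain, would give a readable number. They also leave open whether the number for compound 2 is tied to its 2-methoxyphenyl group.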